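This account rests on a few compounds, and the source may have more. Where it says the series, first, only, none or still open, it means among the compounds named here.

Compound 1 `Cc1cccc(N2CCn3c2n[nH]c(=O)c3=O)c1C` was tested in a functional assay on T47D cells (Homo sapiens) for cytotoxicity, with a stated time of 72 h, tested at 50 ug/mL (on this read-out lower numbers stand for a weaker effect and higher numbers for a stronger effect at the one concentration tested), and gives 22%. Compound 2 `Cc1ccccc1N1CCn2c1n[nH]c(=O)c2=O` gives 0% in this assay. Between them lies one change, (hydrogen in place of methyl on an aromatic carbon), and the step is a number 22 percentage points lower from compound 1 to compound 2 (beyond the scatter). Compound 3 `Cc1ccc(N2CCn3c2n[nH]c(=O)c3=N)cc1` gives 0% in this assay, level with compound 2 at the digits recorded. How the core of compound 3 differs from the core of compound 1 is not broken down here. Compound 4 `N=c1c(=O)[nH]nc2n1CCN2c1ccccc1` is reached from compound 3 by hydrogen in place of methyl on an aromatic carbon, the same kind of change as before, though here the spot is para to a large group, whereas before it was ortho to a methyl group and meta to a large group. Since compound 3 already gives 0%, little room remains downward, so compound 4 is expected to stay low, with an estimated step of a number 3 percentage points higher from compound 3 to compound 4 (within the scatter). The estimate for compound 4 in this assay is 3%, with a range from 0% to 15%.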

Compound 4, a percentage reported as inhibition, at one concentration (the size of the read-out at that concentration, not a potency): 3%
Beside the measured number, compound 4's estimate shows no gap at the digits printed; the range from low to high includes it.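

The new step is a number 3 percentage points higher from compound 3 to compound 4 (within the scatter). Set beside the earlier step, the swap of methyl for hydrogen does not carry over unchanged from one core to the other in this assay: the same change on two cores in this assay, a number 22 percentage points lower (beyond the scatter) from compound 1 to compound 2 and a number 3 percentage points higher (within the scatter) from compound 3 to compound 4, 25 percentage points apart, beyond the scatter of two such steps

This does not show why, and two pairs set no rule for the series: the methyl sits at a different place on the ring in each pair, the cores differ as well, and compound 3 already gives 0%, which leaves little room for any fall.

Still open, going by these compounds, is how the read-out responds when a chlorine atom, a methoxy group or an amine stands on the aromatic ring instead of the methyl. Also open, on these data alone, is which of the two steps the same swap would resemble on further cores.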